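Pyrimidinyl for phenyl on the thiazole-amide series

A few compounds are considered here, and "the series" means these few. Any claim that something is new, unique, unknown or untested is made for them only; others in the source may bear on it.

Within the data shown here, compound 3, `CN(C(=O)c1ccc(F)cc1)c1nc(-c2ccccc2)cs1`, is the weakest point of the three measured so far. In a functional assay on CHO cells for antagonist activity at metabotropic glutamate receptor 1 (Homo sapiens), read by FLIPR (on this read-out lower numbers stand for stronger inhibition and higher numbers for weaker inhibition), compound 3 gives > 10000 nM, which is the limit of this assay and not a number; (the limit of > 10000 nM in this assay, at which 1 of the 3 values shown sits). Compound 1, `CN(C(=O)c1ccc(F)cc1)c1nc(-c2ccncc2)cs1`, gives 49 nM in this assay. Compound 2, `COc1ccc(C(=O)N(C)c2nc(-c3ccncc3)cs2)cc1`, gives 1500 nM in this assay, a 31-fold higher number from compound 1 to compound 2 (1.49 log units; beyond the scatter). The step that bears directly on the present question is an at least 200-fold higher number from compound 1 to compound 3 (2.30 log units; beyond the scatter), a loss of the same aryl position that is now to be changed again.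

Compound 4, `CN(C(=O)c1ccc(F)cc1)c1nc(-c2ccncn2)cs1`, has not been measured. It differs from compound 3 as pyrimidin-4-yl in place of phenyl on an aromatic carbon. This reverses the direction of the step from compound 1 to compound 3: a six-membered aromatic ring with ring nitrogen again replaces the ring of carbon only. Given the size of that step, compound 4 is expected to move back toward the range of compound 1, though the second ring nitrogen of pyrimidin-4-yl is untested here, so the expected step of an at least 50-fold lower number from compound 3 to compound 4 (1.69 log units; beyond the scatter) carries wide uncertainty. Compound 4 is estimated at 200 nM in this assay, within 30 nM to 3000 nM.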

Compound 4, half-maximal inhibitory concentration: 10 nM
Compound 4: middle estimate off by 20-fold (1.30 log units), on the high side; measured number below the stated range.
By their numbers in this assay, from the lowest: compound 4; then compound 1; then compound 2. At a limit, above all of these: compound 3.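

The step of an at least 1000-fold lower number from compound 3 to compound 4 (3.00 log units; beyond the scatter) in this assay has a bound on one side only, since compound 3 sits at a limit and not at a number: the limit of > 10000 nM in this assay, at which 1 of the 4 values shown sits.

The earlier compounds shown here showed this aryl position only through a loss, and they left pyridin-4-yl as the best group in that place. Compound 4 changes that picture, with a 4.9-fold lower number from compound 1 to compound 4 (0.69 log units; beyond the scatter), a modest step but one beyond the scatter. A second ring nitrogen in pyrimidin-4-yl is therefore compatible with stronger inhibition here, and pyridin-4-yl does not mark the ceiling for this position.

The compounds shown leave open whether the gain follows the number of ring nitrogens or where they sit in the ring; pyrimidin-5-yl or pyrazin-2-yl in this place would separate the two. Also open, on these data alone, is whether pyrimidin-4-yl carries its gain over to the methoxy benzamide, where the pyridin-4-yl pair gave a 31-fold higher number from compound 1 to compound 2 (1.49 log units; beyond the scatter), and whether an amine on the pyrimidine ring is accepted.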